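Dropping the Chain Methyl from Compound 2

The compounds below may be only part of what the source reports. "The series", "measured", "known", "first", "only" and "open" are said of these compounds alone.

In an assay (Canis lupus familiaris) for binding affinity to platelet-activating factor receptor (Homo sapiens), read by radioligand binding (a lower number here means a stronger inhibitor, a higher number a weaker inhibitor), compound 2 `COc1cccc(-c2ccc(C(=O)N[C@H](C)CCCc3cccnc3)cc2)c1` gives 20 nM, the second highest of the three numbers shown. Compound 3 `CCc1cc(C(=O)N[C@H](C)CCCc2cccnc2)ccc1-c1ccc(OC)c(OC)c1` gives 4 nM in this assay, and compound 1 `COc1ccc(-c2ccc(C(=O)N[C@H](C)CCCc3cccnc3)cc2Br)cc1OC` gives 180 nM. Within the data shown here, the only step measured between compounds differing in one place, a 45-fold lower number from compound 1 to compound 3 (1.65 log units; beyond the scatter), concerns a substituent on an aromatic carbon and not the chain.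

Compound 4 `COc1cccc(-c2ccc(C(=O)NCCCCc3cccnc3)cc2)c1` differs from compound 2 by hydrogen in place of methyl on a saturated chain carbon bound to an amide-type nitrogen and a saturated chain carbon, that is, a hydrogen in place of methyl on a saturated chain carbon bound to an amide-type nitrogen and a saturated chain carbon. Among the measured compounds shown here, no measured pair bears on this change; the step from compound 1 to compound 3 is of a different kind and cannot set its size. With nothing measured to guide it, the expected step is small, a 2.0-fold higher number from compound 2 to compound 4 (0.30 log units; within the scatter), toward a weaker inhibitor, and it may well fall within the scatter. For compound 4 the estimate in this assay is 40 nM, with a range from 12 nM to 130 nM.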

Compound 4, half-maximal inhibitory concentration: 280 nM
The estimate for compound 4 lay 7.0-fold (0.85 log units) below the measured number; the measured number lies above the stated range.
By their numbers in this assay, from the lowest: compound 3; then compound 2; then compounds 1 and 4 (each within the scatter of the next).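

With hydrogen in place of methyl on a saturated chain carbon bound to an amide-type nitrogen and a saturated chain carbon, this assay shows a 14-fold higher number from compound 2 to compound 4 (1.15 log units; beyond the scatter), toward a weaker inhibitor. Among these compounds, the only earlier step concerned a substituent on an aromatic carbon, so this is the first evidence that the chain position also matters, and here the loss of a single carbon atom carries a large step. Nothing available explains the size of this step.

The compounds shown leave open whether a propyl group or a hydroxymethyl group on this chain carbon would give a lower or a higher number than methyl, and what the mirror-image arrangement at that carbon would give. They also leave open whether removing the methyl would have a similar effect on the cores of compound 1 and compound 3.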